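Isopropyl in Place of Cyclopropyl: Expected Thermal Shift

The source may report more compounds than this note shows. Statements on the series, on what has been measured and on what is new or still open speak of the compounds shown alone.

Of the compounds shown here, two have so far been measured in an assay on isolated protein for inhibition of Ephrin type-A receptor 2 (Homo sapiens), read by thermal shift assay, tested at 10 uM; on this read-out lower numbers stand for weaker stabilisation of the target and higher numbers for stronger stabilisation of the target against heat. Compound 1 `CC(C)(C)c1cc(NC(=O)Nc2ccc(Cl)cc2)n(-c2ccc(N)cc2)n1` carries a free amino group on an aromatic ring, and in this assay compound 1 gives 2 degrees C. Compound 2 `CC(C)(C)c1cc(NC(=O)Nc2ccc(Cl)cc2)n(-c2ccc(NC(=O)C3CC3)cc2)n1` bears a cyclopropylcarbonyl on that nitrogen instead, and in this assay compound 2 gives 3 degrees C. The step of a number 1.0 degrees C higher from compound 1 to compound 2 (within the scatter) lies within the scatter, so compound 2 holds the higher of the two numbers only by a margin the method cannot resolve.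

Compound 3 `CC(C)C(=O)Nc1ccc(-n2nc(C(C)(C)C)cc2NC(=O)Nc2ccc(Cl)cc2)cc1` differs from compound 2 by isopropyl in place of cyclopropyl on a carbonyl carbon, with the amide-type nitrogen and carbonyl kept. Going by the values given here, no measured step touches this position; the single step available, a number 1.0 degrees C higher from compound 1 to compound 2 (within the scatter), concerns attaching the whole cyclopropylcarbonyl group and stayed within the scatter. With both groups of three carbons and no donors or acceptors, no step beyond the scatter is expected here. Compound 3 is therefore expected to give 3 degrees C, in a range from 1.5 degrees C to 4.5 degrees C, an expected step of no change at the digits printed from compound 2 to compound 3 (within the scatter).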

Compound 3, shift of the target's melting temperature: 2.8 degrees C
The estimate for compound 3 lay 0.20 degrees C above the measured number; measured number inside the range.
By their numbers in this assay, from the lowest: compounds 1, 3 and 2 (each within the scatter of the next).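

Going by these compounds alone, this is the first reading at the position itself: in this assay, isopropyl in place of cyclopropyl on a carbonyl carbon gives a number 0.20 degrees C lower from compound 2 to compound 3 (within the scatter), so an open group of three carbons can stand where the three-membered ring stood with no difference this method can resolve. Isopropylcarbonyl in place of hydrogen on the nitrogen gives a number 0.80 degrees C higher from compound 1 to compound 3 (within the scatter), so this group, like cyclopropylcarbonyl, cannot be told apart from the free amino group of compound 1. Nothing at hand explains why these numbers lie so close together.

Still open, from the compounds shown here alone, is whether any group on this carbonyl carbon can move the number beyond the scatter, for example a longer chain such as butyl, an amine or a carboxylic acid. With all three compounds this close, the read-out gives no sign yet of how much this position matters.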